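Adding a Methyl Where Both Neighbours Show Only Limits

The source may report more compounds than this note shows. Statements on the series, on what has been measured and on what is new or still open speak of the compounds shown alone.

Compound 1 `CC(c1nccs1)C(C#N)C#N`: in a functional assay on SH-SY5Y cells (Homo sapiens) for cytotoxicity, read by MTT assay, with a stated time of 48 h (a lower number here means a stronger inhibitor, a higher number a weaker inhibitor), compound 1 gives only a limit, > 120000 nM.
Compound 2 `N#CC(C#N)Cc1nccs1`: in this assay compound 2 gives only a limit, > 120000 nM.

Compound 1 stands on no measured number at all; its value is the limit of > 120000 nM in this assay, at which 2 of the 2 values shown sit. Compound 3 `CC(C)(c1nccs1)C(C#N)C#N` differs from compound 1 by methyl in place of hydrogen on a saturated chain carbon bound to an aromatic carbon and two saturated chain carbons. Going by the values given here, the only measured step that bears on this, a step that the two limits leave unreadable from compound 1 to compound 2, runs between two limits, so its size cannot be read. No size or direction of step in this assay can therefore be expected from the data, beyond the scatter or within it. Compound 3 is estimated at 150000 nM, between 60000 nM and 400000 nM, and will most likely again appear only as a limit. The expected step is a step that the limit leaves unreadable from compound 1 to compound 3.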

Compound 3, half-maximal inhibitory concentration: > 120000 nM
Compound 3: only a limit was reported (the forecaster's own chance of this, stated with the estimate: 85%); the middle value is on the limit's open side.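

Going by these compounds alone, compound 1, compound 2 and compound 3 all give only limits in this assay, so no step between them can be read. Whether methyl or hydrogen at this place changes cytotoxicity at all stays open: the limit of > 120000 nM in this assay, at which 3 of the 3 values shown sit.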